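A few compounds are considered here, and "the series" means these few. Any claim that something is new, unique, unknown or untested is made for them only; others in the source may bear on it.

Measured compounds and their values in a functional assay, read by MTT assay, with a stated time of 4 h; on this read-out higher numbers stand for weaker inhibition and lower numbers for stronger inhibition:

Compound 1, `Oc1ccc(Cc2cccc(Cl)c2)cc1O`: 223000 nM
Compound 2, `O=C(c1ccc(O)c(O)c1)c1c(Cl)c(O)c(O)c(O)c1Cl`: 87300 nM
Compound 3, `Oc1cc(Br)c(Cc2ccccc2)cc1O`: 164000 nM

Of the compounds shown here, three have been measured in this assay so far. All three are weak inhibitors, with half-maximal inhibitory concentrations far into the micromolar range. Compound 3 gives a number that sits between those of compound 1 and compound 2, but the gap to each of them stays within the usual scatter of repeated measurements, so on present evidence none of the three can be told apart from the others.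

Compound 4, `Oc1cc(Cc2ccccc2)c(Br)c(Br)c1O`, has not yet been measured. It differs from compound 3 in a single place: bromo in place of hydrogen on an aromatic carbon. Among the measured compounds shown here, the new bromo group sits on the same ring that carries the two hydroxy groups and the first bromo group of compound 3.

For the measured compounds named here, no pair of measured compounds differs in exactly this way, so there is no directly comparable step to lean on. Within the set shown, compounds 1 and 3 already carry one halogen each and give numbers that cannot be separated, which gives no reason to expect a large jump from a second bromo group. The step from compound 3 to compound 4 is therefore expected to be small, at most a modest move toward stronger inhibition and quite possibly none beyond the scatter, an expected 1.4-fold lower number from compound 3 to compound 4 (0.14 log units; within the scatter). For compound 4 the estimated value in this assay is 120000 nM, with a range from 50000 nM to 300000 nM.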

Compound 4, half-maximal inhibitory concentration: 88000 nM
Beside the measured number, compound 4's estimate is 1.4-fold (0.13 log units) above it, within the range that was stated.
By their numbers in this assay, from the lowest: compounds 2, 4, 3 and 1 (each within the scatter of the next, the first and the last beyond it).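

In this assay, bromo in place of hydrogen on this aromatic carbon gives a 1.9-fold lower number from compound 3 to compound 4 (0.27 log units; within the scatter), the first direct view of a change at this position, which is ortho to a bromo group and ortho to a hydroxy group. The step shows that this carbon can take a second bromo group without the number moving beyond the usual scatter of repeated measurements, but a single step of this size cannot separate a small real gain from no gain at all. No measurement shown bears on what lies behind this result.

The compounds shown leave open whether this carbon would give a different number with a group other than bromo, such as a methyl group, an amine or a carboxylic acid. They also leave open how the new bromo group behaves without the first bromo group, and whether either hydroxy group could be replaced by a methoxy group, so the contribution of each substituent on this ring remains unresolved.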